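Exchanging One Benzyl Group, Little Change Expected

This account rests on a few compounds, and the source may have more. Where it says the series, first, only, none or still open, it means among the compounds named here.

Compound 3 `COc1ccc([C@@H]2CC(=O)c3c(O)cc(OCc4cn(Cc5ccccc5F)nn4)cc3O2)cc1O` belongs to a small set of three related compounds. In a functional assay on RAW264.7 cells (Mus musculus) for inhibition, read by Griess assay, with stated times of 2 h and 24 h (on this read-out higher numbers stand for weaker inhibition and lower numbers for stronger inhibition), compound 3 gives 7320 nM. Compound 1 `CCCCn1cc(COc2cc(O)c3c(c2)O[C@H](c2ccc(OC)c(O)c2)C/C3=N\O)nn1` gives 8900 nM in this assay, and compound 2 `COc1ccc([C@@H]2C/C(=N\O)c3c(O)cc(OCc4cn(CC5CC5)nn4)cc3O2)cc1O` gives 6320 nM in this assay. Compound 3 thus holds the second highest of the three numbers, yet its gap to each of the other two lies within the scatter of repeated measurements, so the three cannot truly be told apart. For the measured compounds named here, the only measured step, a 1.4-fold lower number from compound 1 to compound 2 (0.15 log units; within the scatter), concerns a different part of the molecule and is itself within the scatter.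

Compound 4 `COc1ccc([C@@H]2CC(=O)c3c(O)cc(OCc4cn(Cc5ccc(C)cc5)nn4)cc3O2)cc1O` is the compound still to be measured. It differs from compound 3 in one place: 4-methylphenyl in place of 2-fluorophenyl on a saturated chain carbon bound to an aromatic nitrogen. Going by the values given here, no measured step covers this kind of exchange, so the only guide is that the single recorded change elsewhere in the molecule left the number essentially unmoved. On that basis the step from compound 3 to compound 4 is expected to be a 1.0-fold lower number from compound 3 to compound 4 (0.02 log units; within the scatter), no larger than the scatter. Compound 4 is therefore estimated at 7000 nM in this assay, with a range from 3500 nM to 14000 nM.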

Compound 4, half-maximal inhibitory concentration: 16800 nM
Compound 4: middle estimate off by 2.4-fold (0.38 log units), on the low side; the whole stated range lies below it.
By their numbers in this assay, from the lowest: compounds 2, 3, 1 and 4 (each within the scatter of the next, the first and the last beyond it).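

In this assay, for the compounds shown here, the exchange of 2-fluorobenzyl for 4-methylbenzyl gives a 2.3-fold higher number from compound 3 to compound 4 (0.36 log units; beyond the scatter) and is the first step here that lies beyond the scatter, so the group on this saturated chain carbon bound to an aromatic nitrogen can shift the number, if only modestly. The two names differ both in the atom or group carried by the ring and in where it sits, so this single step cannot separate those two changes. No accompanying measurement bears on why the number rises.

Still open, as far as these compounds go, is where a plain unsubstituted phenyl, or a ring carrying a chlorine atom or a methoxy group, would fall. Also open, from the compounds shown here alone, is whether the same exchange would move the number similarly on the core of compound 1.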